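This account rests on a few compounds, and the source may have more. Where it says the series, first, only, none or still open, it means among the compounds named here.

Measured so far in an assay on isolated protein for inhibition of DNA topoisomerase 1 (Homo sapiens), tested at 100 uM; on this read-out lower numbers stand for a weaker effect and higher numbers for a stronger effect at the one concentration tested:
- compound 1 `COc1cc(O)ccc1/C=C/C(=O)c1ccc(N)cc1` gives 0.8%
- compound 2 `COc1ccc(/C=C/C(=O)c2ccc(O)cc2)cc1Br` gives 24.8%
- compound 3 `O=C(/C=C/c1ccc(N2CCCC2)cc1)c1ccc(O)cc1O` gives 87.1%

Compound 2 stands second highest of the three; its nearest neighbour is compound 1, which lies lower by a gap beyond the scatter, and its furthest is compound 3, which lies higher by a gap well beyond the scatter.

Compound 4 `COc1ccc(/C=C/C(=O)c2ccc(O)cc2O)cc1Br` is the next member to be tested in this assay. It differs from compound 2 by one change: hydroxy in place of hydrogen on an aromatic carbon. Within the data shown here, no step between measured compounds covers this change, so the direction can only be guessed from the spread of the three numbers. Among the measured compounds shown here, a moderate increase is expected, since compound 3 is the only one carrying two hydroxy groups and gives the highest number. The expected step from compound 2 to compound 4 is a number 20.2 percentage points higher from compound 2 to compound 4 (beyond the scatter). Compound 4 is estimated at 45%, in a range from 20% to 75%.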

Compound 4, a percentage reported as inhibition, at one concentration (the size of the read-out at that concentration, not a potency): 73.2%
Compound 4: middle estimate off by 28.2 percentage points, on the low side; the measured number falls inside the stated range.
By their numbers in this assay, from the lowest: compound 1; then compound 2; then compound 4; then compound 3.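

Hydroxy in place of hydrogen on an aromatic carbon, ortho to a large group and meta to a hydroxy group, gives a number 48.4 percentage points higher from compound 2 to compound 4 (beyond the scatter) in this assay and is the first step in the series between compounds differing in one place. This position therefore responds strongly to a single added hydroxy group on the core of compound 2. Still open, as far as these compounds go, is whether fluoro, an amine or a carboxylic acid at this place would give a step of similar size, and whether hydroxy gives such a step on a core without the bromo group. Nothing at hand gives a reason for the size of this step.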